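Series notes: phenethyl in place of 3,4-dimethoxyphenyl

This account rests on a few compounds, and the source may have more. Where it says the series, first, only, none or still open, it means among the compounds named here.

Measured so far:
compound 1 `C=C(Br)C(=O)Nc1cccc(-c2cn3nc(-c4ccc(OC)c(OC)c4)sc3n2)c1`: 42 nM
compound 2 `C=C(Br)C(=O)Nc1cccc(-c2cn3c(-c4ccccc4)csc3n2)c1`: 1300 nM

In a functional assay on L1210 cells (Mus musculus) for inhibition, read by cell counting, with a stated time of 2 days (on this read-out lower numbers stand for stronger inhibition and higher numbers for weaker inhibition), compound 1 gives 42 nM, the lower of the two numbers; compound 2 gives 1300 nM, a gap beyond the scatter. Compound 3 `C=C(Br)C(=O)Nc1cccc(-c2cn3nc(CCc4ccccc4)sc3n2)c1` is not yet measured. It differs from compound 1 in one place: phenethyl in place of 3,4-dimethoxyphenyl on an aromatic carbon. For the measured compounds named here, no step between two measured compounds covers this change, so the expectation rests on compound 1 alone. A step of moderate size towards weaker inhibition is expected, a 7.1-fold higher number from compound 1 to compound 3 (0.85 log units; beyond the scatter), with little firm ground for its size. Compound 3 is estimated at 300 nM, in the range 60 nM to 1500 nM.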

Compound 3, half-maximal inhibitory concentration: 2200 nM
Compound 3: the middle estimate sits 7.3-fold (0.87 log units) below what was measured; measured number outside the range, above it.
By their numbers in this assay, from the lowest: compound 1; then compounds 2 and 3 (each within the scatter of the next).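

In this assay, the aromatic carbon next to the ring sulfur proves sensitive to its substituent: phenethyl in place of 3,4-dimethoxyphenyl gives a 52-fold higher number from compound 1 to compound 3 (1.72 log units; beyond the scatter) and counts as a large step. Compound 3 keeps a six-membered aromatic ring of carbon only in its substituent, so that ring alone does not preserve the number of compound 1. Nothing at hand accounts for the loss. On these data alone, it remains open whether the two methoxy groups or the two-carbon link matters more. A 3,4-dimethoxyphenethyl group at this place would help separate the two.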